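Sulfonyl aryl exchange in the kallikrein-7 series

The compounds below may be only part of what the source reports. "The series", "measured", "known", "first", "only" and "open" are said of these compounds alone.

Compound 1 `CC1=NC(c2cn(S(=O)(=O)c3ccc(Cl)cc3)c3ccc(C)cc23)CN1` gives no number in an assay on isolated protein for inhibition of kallikrein-7 (Mus musculus), read by fluorescence, with stated times of 10 min and 30 min (on this read-out higher numbers stand for weaker inhibition and lower numbers for stronger inhibition), but only a limit of > 100000 nM in that assay. Going by the values given here, compound 2 `CC1=NC(c2cn(S(=O)(=O)c3ccccc3)c3ccc(C)cc23)CN1` gives 15000 nM in this assay and so holds the only measured number of the series. The step of an at least 6.6-fold lower number from compound 1 to compound 2 (0.82 log units; beyond the scatter) is therefore a bound rather than a number, set by the limit of > 100000 nM in this assay, at which 1 of the 2 values shown sits, rather than by a measured pair. Compound 3 `CC1=NC(c2cn(S(=O)(=O)c3cccs3)c3ccc(C)cc23)CN1` carries thiophen-2-yl in place of phenyl on a sulfonyl sulfur on the shared core. Among the compounds with values here, no measured step concerns the aryl ring on the sulfonyl sulfur itself; the single step of an at least 6.6-fold lower number from compound 1 to compound 2 (0.82 log units; beyond the scatter) concerns only a substituent on that ring and shows that what sits on the sulfonyl sulfur can shift the read-out by at least a modest amount. For an exchange of the ring with no substituent added or removed, the expected step is a 1.3-fold lower number from compound 2 to compound 3 (0.10 log units; within the scatter) and so no change beyond the scatter is expected. Compound 3 is accordingly estimated at 12000 nM in this assay with a range from 4000 nM to 40000 nM around it.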

Compound 3, half-maximal inhibitory concentration: 22000 nM
For compound 3 the middle estimate is 1.8-fold (0.26 log units) below the measured one; measured number inside the range.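

In this assay the ring on the sulfonyl sulfur has now been exchanged with no substituent added or removed, and the step is a 1.5-fold higher number from compound 2 to compound 3 (0.17 log units; within the scatter), so thiophen-2-yl and phenyl cannot be told apart on this read-out. The series now also holds an at least 4.5-fold lower number from compound 1 to compound 3 (0.65 log units; beyond the scatter), which points the same way as an at least 6.6-fold lower number from compound 1 to compound 2 (0.82 log units; beyond the scatter), so both rings without a substituent stand apart from 4-chlorophenyl by more than the scatter. Both steps are bounds and not measured differences, set by the limit held by compound 1: the limit of > 100000 nM in this assay, at which 1 of the 3 values shown sits.

It remains open whether these bounds belong to chloro in particular or to any substituent on the phenyl ring, and the compounds shown offer no fluoro, methyl or methoxy on that ring to decide it. Also open, going by these compounds, is what an amine or a carboxylic acid on the ring would do, or a cyclohexyl or a plain methyl on the sulfonyl sulfur in place of the aromatic ring, and whether any such change gives a number clearly lower than those of compound 2 and compound 3.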